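Working notes: the lactam exchange leading to compound 4

The compounds below may be only part of what the source reports. "The series", "measured", "known", "first", "only" and "open" are said of these compounds alone.

Measured in a physicochemical assay for solubility, with a stated time of 18 h, at pH 7.4; a higher number here means a more soluble compound, a lower number a less soluble compound:
compound 1 `O=C1COCCN1c1ccc(C2CC(c3ccc([N+](=O)[O-])o3)=NO2)cn1` gives 21.9 ug/mL
compound 2 `O=C1COCCN1c1ccc(C2CC(c3ccc([N+](=O)[O-])o3)=NO2)cc1F` gives 12.6 ug/mL
compound 3 `CN1CCN(c2ccc(C3CC(c4ccc([N+](=O)[O-])o4)=NO3)cc2F)C(=O)C1` gives 29.2 ug/mL

Compound 1 (21.9 ug/mL) stands within the scatter of both compound 2 (12.6 ug/mL) and compound 3 (29.2 ug/mL), so its place among the three numbers carries little weight. The next structure is compound 4 `CN1CCN(c2ccc(C3CC(c4ccc([N+](=O)[O-])o4)=NO3)cn2)C(=O)C1`, which keeps the core of compound 1 and changes one group: 4-methyl-2-oxopiperazin-1-yl in place of 3-oxomorpholin-4-yl on an aromatic carbon. The exchange is 4-methyl-2-oxopiperazin-1-yl in place of 3-oxomorpholin-4-yl, on an aromatic carbon next to the ring nitrogen, para to a large group.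

The same exchange has been measured once, on a different core: a 2.3-fold higher number from compound 2 to compound 3 (0.37 log units; beyond the scatter). That step is modest but beyond the scatter, and a single pair establishes no pattern. Within the data shown here, it is nevertheless the only guide, and the estimate applies it to compound 1 at 21.9 ug/mL. A higher number of similar size is expected in this assay, an estimated 2.1-fold higher number from compound 1 to compound 4 (0.31 log units; beyond the scatter). For compound 4 the estimated value is 45 ug/mL, with an expected range of 24 ug/mL to 85 ug/mL.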

Compound 4, solubility: 28.9 ug/mL
Compound 4: middle estimate off by 1.6-fold (0.19 log units), on the high side; low and high end bracket the measured number.
By their numbers in this assay, from the lowest: compounds 2, 1, 4 and 3 (each within the scatter of the next, the first and the last beyond it).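

On the core of compound 1, in this assay, the exchange of 3-oxomorpholin-4-yl for 4-methyl-2-oxopiperazin-1-yl on an aromatic carbon next to the ring nitrogen, para to a large group, gives a 1.3-fold higher number from compound 1 to compound 4 (0.12 log units; within the scatter) and so leaves the two compounds indistinguishable in this read-out. On the core of compound 2 the same exchange gives a 2.3-fold higher number from compound 2 to compound 3 (0.37 log units; beyond the scatter) and the reading beyond the scatter found there does not carry over to this position, so the exchange now has one pair beyond the scatter and one within it, and no general effect of the exchange can be claimed from these two pairs. Nothing available bears on why the two pairs read differently.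

As far as these compounds go, whether the exchange reads beyond the scatter on a third core remains open, since two pairs cannot show how far the outcome depends on the core. Also open, from the compounds shown here alone, is how this assay would read with a carboxylic acid, a primary amine or a longer alkyl chain in place of the methyl of 4-methyl-2-oxopiperazin-1-yl on the core of compound 1.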